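Lengthening the Phenoxyalkyl Chain of an Acrylic Acid Antagonist

This account rests on a few compounds, and the source may have more. Where it says the series, first, only, none or still open, it means among the compounds named here.

Compound 1, `Cc1ccc(/C=C/C(=O)O)c(OCCC2(C)CCc3c(C)c(O)c(C)c(C)c3O2)c1`, gives 3100 nM in an in vitro functional assay on CHO cells for antagonist activity at prostaglandin E2 receptor EP3 subtype (Mus musculus); a higher number here means a weaker inhibitor, a lower number a stronger inhibitor.
Compound 2, `COc1ccc(/C=C/C(=O)O)c(OCCC2(C)CCc3c(C)c(O)c(C)c(C)c3O2)c1`, reaches only the assay limit of > 10000 nM in this assay.
Compound 3, `O=C(O)/C=C/c1ccc(Cn2ccnc2)cc1OCCCOc1ccccc1`, gives 3000 nM in this assay.

Of the two numbers shown, compound 3 sits within the scatter of compound 1. Compound 2 gave only a limit, (the limit of > 10000 nM in this assay, at which 1 of the 3 values shown sits). Compound 4, `O=C(O)/C=C/c1ccc(Cn2ccnc2)cc1OCCCCOc1ccccc1`, differs from compound 3 by phenoxymethyl in place of phenoxy on a saturated chain carbon, three bonds along the chain from an oxygen on an aromatic ring. Going by the values given here, the only measured step, an at least 3.2-fold higher number from compound 1 to compound 2 (0.50 log units; beyond the scatter), concerns a substituent on the aromatic ring of the shared core of compound 1 and offers no guidance on a lengthened chain. Among the compounds with values here, with no comparable step available, the chain extension is expected to leave the number within the scatter: no change at the digits printed from compound 3 to compound 4 (within the scatter). Compound 4 is therefore estimated at 3000 nM, in a range from 1200 nM to 8000 nM.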

Compound 4, half-maximal inhibitory concentration: 3500 nM
Compound 4: middle estimate off by 1.2-fold (0.07 log units), on the low side; measured number inside the range.
By their numbers in this assay, from the lowest: compounds 3, 1 and 4 (each within the scatter of the next). At a limit, above all of these: compound 2.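

Phenoxymethyl in place of phenoxy at this saturated chain carbon gives a 1.2-fold higher number from compound 3 to compound 4 (0.07 log units; within the scatter) in this assay. Going by these compounds alone, this is the first reading on the chain itself, since the earlier step concerned only a substituent on the aromatic ring of the shared core, and it shows that this added chain carbon leaves the number within the scatter. No measured property shown here bears on this result.

The compounds shown leave open whether a longer chain, such as 2-phenoxyethyl at this place, would also leave the number within the scatter. They also leave open what an amine in place of the phenoxy group would do.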